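The source may report more compounds than this note shows. Statements on the series, on what has been measured and on what is new or still open speak of the compounds shown alone.

Measured so far:
compound 1 `CC(C)/N=C(\S)OC[C@H]1OC(n2cnc3c(NC4CCOC4)ncnc32)[C@H](O)[C@@H]1O`: 36 nM
compound 2 `O=C(NC1CCCC1)OC[C@H]1OC(n2cnc3c(NC4CCOC4)nc(Cl)nc32)[C@H](O)[C@@H]1O`: 226 nM

In an assay on DDT1 cells (Cricetulus griseus) for binding affinity to adenosine receptor A1 (Homo sapiens), read by radioligand binding (a higher number here means a weaker inhibitor, a lower number a stronger inhibitor), compound 1 gives 36 nM, the lower of the two numbers; compound 2 gives 226 nM, and that gap lies beyond the usual scatter. Going by the values given here, compound 2 differs from compound 1 in more than one place, so no single step is defined between them. Compound 3 `C=CC/N=C(\S)OC[C@H]1OC(n2cnc3c(NC4CCOC4)ncnc32)[C@H](O)[C@@H]1O` has not yet been measured in this assay. It differs from compound 1 in one place: allyl in place of isopropyl on a double-bonded nitrogen. Among the compounds with values here, no measured pair covers this change, so little movement is expected, with compound 3 estimated at 40 nM, in a range from 15 nM to 110 nM. The estimated step is a 1.1-fold higher number from compound 1 to compound 3 (0.05 log units; within the scatter), expected to stay within the scatter.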

Compound 3, inhibition constant: 35 nM
The estimate for compound 3 lay 1.1-fold (0.06 log units) above the measured number; low and high end bracket the measured number.
By their numbers in this assay, from the lowest: compounds 3 and 1 (each within the scatter of the next); then compound 2.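

In this assay, allyl in place of isopropyl on the double-bonded nitrogen gives a 1.0-fold lower number from compound 1 to compound 3 (0.01 log units; within the scatter), which lies within the scatter. Going by these compounds alone, this is the first single-place comparison at this position, and it shows that a double bond in this group leaves the number unchanged within the scatter. No available evidence explains this match.

The compounds shown compare only isopropyl and allyl at this position. They leave open whether a longer chain or a benzyl group there would also hold the number.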